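Compound 4: trimethoxyphenyl step from compound 3

The compounds below may be only part of what the source reports. "The series", "measured", "known", "first", "only" and "open" are said of these compounds alone.

Among the compounds with values here, compound 3 `C=CC(=O)Nc1cccc(NC(=O)CSc2nc(Nc3cccc(OC)c3)c3ccccc3n2)c1` gives 34900 nM in a functional assay on PC-3 cells (Homo sapiens) for inhibition, read by MTT assay, with a stated time of 72 h (a lower number here means a stronger inhibitor, a higher number a weaker inhibitor), the highest number of the three measured so far; compound 1 `C=CC(=O)Nc1cccc(NC(=O)CSc2nc(Nc3ccccc3)c3ccccc3n2)c1` gives 8740 nM and compound 2 `C=CC(=O)Nc1cccc(NC(=O)CSc2nc(Nc3cccc(Br)c3)c3ccccc3n2)c1` gives 15000 nM. Compound 4 `C=CC(=O)Nc1cccc(NC(=O)CSc2nc(Nc3cc(OC)c(OC)c(OC)c3)c3ccccc3n2)c1` differs from compound 3 by 3,4,5-trimethoxyphenyl in place of 3-methoxyphenyl on a nitrogen on an aromatic ring. Within the data shown here, the steps that bear on this change are a 4.0-fold higher number from compound 1 to compound 3 (0.60 log units; beyond the scatter) and a 2.3-fold higher number from compound 2 to compound 3 (0.37 log units; beyond the scatter), both running towards higher numbers as methoxy enters; a 1.7-fold higher number from compound 1 to compound 2 (0.23 log units; within the scatter) is within the scatter. A further modest rise is therefore expected, with a step of a 1.7-fold higher number from compound 3 to compound 4 (0.24 log units; within the scatter) resting on a 4.0-fold higher number from compound 1 to compound 3 (0.60 log units; beyond the scatter). Compound 4 is estimated at 60000 nM, with a range from 20000 nM to 150000 nM, and a real chance that only a limit is reported.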

Compound 4, half-maximal inhibitory concentration: > 50000 nM
Compound 4 gave a limit, no number (the forecaster's own chance of this, stated with the estimate: 25%); the middle value is on the limit's open side.
By their numbers in this assay, from the lowest: compounds 1 and 2 (each within the scatter of the next); then compound 3. At a limit, above all of these: compound 4.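

In this assay compound 4 gives only a limit, > 50000 nM, so this assay puts no number on 3,4,5-trimethoxyphenyl at this nitrogen. The step of an at least 1.4-fold higher number from compound 3 to compound 4 (0.15 log units; that floor lies within the scatter) has a floor that does not separate the two methoxy-bearing compounds, so any cost of the added methoxy groups stays unsized. Against the compounds without methoxy the change does register: an at least 3.3-fold higher number from compound 2 to compound 4 (0.52 log units; beyond the scatter) and an at least 5.7-fold higher number from compound 1 to compound 4 (0.75 log units; beyond the scatter).

Open, on these data alone, is whether an amine or a carboxylic acid on this phenyl ring would bring the number under that of compound 1, 8740 nM.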